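Sulfone to sulfonamide on the shared core of compound 1

A few compounds are considered here, and "the series" means these few. Any claim that something is new, unique, unknown or untested is made for them only; others in the source may bear on it.

Measured so far:
compound 1 `Cn1c(=O)c(S(=O)(=O)c2ccc(F)cc2[N+](=O)[O-])cc2cnc(Nc3ccc4[nH]ccc4c3)nc21` — 900 nM
compound 2 `Cn1c(=O)c(S(=O)(=O)c2ccc(F)cc2)cc2cnc(Nc3ccc4occc4c3)nc21` — 5000 nM

Both numbers come from a functional assay on K562 cells (Homo sapiens) for inhibition, read by trypan blue exclusion, with a stated time of 72 h; a higher number here means a weaker inhibitor, a lower number a stronger inhibitor. Compound 1 holds the lower of the two values; compound 2 lies beyond the usual scatter above it. The two compounds differ in more than one place, so nothing is drawn from that gap beyond what the two values show.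

Compound 3 `Cn1c(=O)c(S(=O)(=O)Nc2ccc(F)cc2F)cc2cnc(Nc3ccc4[nH]ccc4c3)nc21` is the next compound for this assay. Its change from compound 1 is (2,4-difluorophenyl)amino in place of 4-fluoro-2-nitrophenyl on a sulfonyl sulfur. Among the compounds with values here, no measured pair shows this kind of exchange on a sulfonyl sulfur, so the expectation rests on compound 1 alone. A modest step is expected from compound 1 to compound 3, most likely toward a weaker inhibitor, and it may not reach beyond the scatter: a 1.7-fold higher number from compound 1 to compound 3 (0.22 log units; within the scatter) is the expected shift. Compound 3 is therefore estimated at 1500 nM in this assay, with a plausible range from 400 nM to 6000 nM.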

Compound 3, half-maximal inhibitory concentration: 5000 nM
Beside the measured number, compound 3's estimate is 3.3-fold (0.52 log units) below it; measured number inside the range.
By their numbers in this assay, from the lowest: compound 1; then compounds 2 and 3 (each within the scatter of the next).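

In this assay, within the data shown here, the exchange of 4-fluoro-2-nitrophenyl for (2,4-difluorophenyl)amino on a sulfonyl sulfur gives a 5.6-fold higher number from compound 1 to compound 3 (0.74 log units; beyond the scatter), the first one-place step, and it shows that this position responds to the change while still allowing a measurable value. The step cannot be assigned to a single feature: the entering group brings a nitrogen link to the sulfonyl sulfur and a hydrogen-bond donor, while the nitro group and its hydrogen-bond acceptors leave and a second fluorine enters. No measurement at hand accounts for the size or direction of this step.

The compounds shown leave open whether the step follows the nitrogen link or the change of ring substituents, as no pair here holds the same aryl ring on both kinds of link. A sulfonamide carrying a methyl group on its nitrogen, or a saturated amine such as morpholine on the sulfonyl sulfur, would separate the role of the amide hydrogen from that of the aromatic ring.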